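Replacing cyclohexylamino with azetidin-1-yl on compound 2

The compounds below may be only part of what the source reports. "The series", "measured", "known", "first", "only" and "open" are said of these compounds alone.

Compound 1 `CCOc1ccc(NC2=CC(=O)c3c(nc4n3[C@H]3OC[C@@H](O)[C@H]3OC4)C2=O)cc1` is reported in a functional assay on ECa-109 cells for inhibition, with ECa-109 cell line (Homo sapiens) as the target, read by sulforhodamine B assay (on this read-out lower numbers stand for stronger inhibition and higher numbers for weaker inhibition), only as a limit of the assay, > 4000 nM.
Compound 2 `O=C1C(NC2CCCCC2)=CC(=O)c2c1nc1n2[C@H]2OC[C@@H](O)[C@H]2OC1` is likewise reported in this assay only as a limit, > 16000 nM.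
Compound 3 `O=C1C(Nc2ccc(C(F)(F)F)cc2)=CC(=O)c2c1nc1n2[C@H]2OC[C@@H](O)[C@H]2OC1` gives an actual number in this assay, 2250 nM.

Compound 2 therefore has no number of its own and stands at the weaker end of what is shown; of the three results, two are limits and only compound 3 carries a measured value. Compound 4 `O=C1C(N2CCC2)=CC(=O)c2c1nc1n2[C@H]2OC[C@@H](O)[C@H]2OC1` differs from compound 2 by azetidin-1-yl in place of cyclohexylamino on a double-bonded ring carbon.

Both measured steps from compound 2 swap the group on the amine nitrogen. The step of an at least 7.1-fold lower number from compound 2 to compound 3 (0.85 log units; beyond the scatter) shows that exchanging the cyclohexyl for an aromatic ring lowers the number clearly, whereas a step that the two limits leave unreadable from compound 1 to compound 2 gives no readable size. Azetidin-1-yl is again a small non-aromatic ring, so no comparable gain is expected; most likely the assay returns a limit once more. Compound 4 is expected near 20000 nM, between 6000 nM and 60000 nM. The expected step is a step that the limit leaves unreadable from compound 2 to compound 4, which is no change beyond the scatter.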

Compound 4, half-maximal inhibitory concentration: > 16000 nM
Compound 4: a limit, no number; the forecaster's own chance of this, stated with the estimate: 65%; the middle value is on the limit's open side.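

Compound 2 and compound 4 both end at the same limit of the assay, not at an actual number, so the step between them cannot be read: the limit of > 16000 nM in this assay, at which 2 of the 4 values shown sit.

The compounds shown leave open how azetidin-1-yl and cyclohexylamino truly compare on this core.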